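The compounds below may be only part of what the source reports. "The series", "measured", "known", "first", "only" and "open" are said of these compounds alone.

Compound 3, `CC(C)c1cc(N)c2cc(NC(=O)/C=C/c3ccc(C(F)(F)F)cc3)ccc2n1`, gives 2.1 nM in an assay on isolated protein for displacement of a labelled ligand from melanin-concentrating hormone receptor 1 (Homo sapiens) (a lower number here means a stronger inhibitor, a higher number a weaker inhibitor), the second highest of the three numbers recorded there. Nearest to it is compound 1, `CCc1cc(N)c2cc(NC(=O)/C=C/c3ccc(C(F)(F)F)cc3)ccc2n1`, which gives 1.2 nM; furthest is compound 2, `CCCc1cc(OC)c2cc(NC(=O)/C=C/c3ccc(C(F)(F)F)cc3)ccc2n1`, which gives 26 nM. For the measured compounds named here, the only measured step that speaks to chain branching is a 1.8-fold higher number from compound 1 to compound 3 (0.24 log units; within the scatter). Compound 4, `CCC(C)c1cc(N)c2cc(NC(=O)/C=C/c3ccc(C(F)(F)F)cc3)ccc2n1`, differs from compound 3 in one place: methyl in place of hydrogen on a saturated chain carbon, two bonds along the chain from an aromatic carbon. That earlier step added a methyl one bond closer to the ring and stayed within the scatter, so for compound 4 a similarly small step is expected in this assay, most likely a modest rise in the number, a 1.7-fold higher number from compound 3 to compound 4 (0.22 log units; within the scatter). Compound 4 is therefore estimated at 3.5 nM, with a range from 1.2 nM to 10 nM.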

Compound 4, half-maximal inhibitory concentration: 0.3 nM
Beside the measured number, compound 4's estimate is 12-fold (1.07 log units) above it; the measured number lies below the stated range.
By their numbers in this assay, from the lowest: compound 4; then compounds 1 and 3 (each within the scatter of the next); then compound 2.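

Extending isopropyl to sec-butyl gives a 7.0-fold lower number from compound 3 to compound 4 (0.85 log units; beyond the scatter) in this assay, which shows that this position responds to added carbon more than the earlier branching step, a 1.8-fold higher number from compound 1 to compound 3 (0.24 log units; within the scatter), had suggested. Measured against the ethyl group of compound 1, sec-butyl gives a 4.0-fold lower number from compound 1 to compound 4 (0.60 log units; beyond the scatter) and so a methyl two bonds along the chain from an aromatic carbon does more here than one on the carbon bound to it. Nothing available accounts for this gain. As far as these compounds go, whether a longer chain, a cyclopentyl ring or an ether oxygen in the chain would lower the number further stays open.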